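From a Hydroxyphenyl Ring to a Chlorophenyl Ring

This account rests on a few compounds, and the source may have more. Where it says the series, first, only, none or still open, it means among the compounds named here.

Compound 2 `CC1=CC[C@H](C(C)(C)NC(=S)N/N=C/c2ccccc2O)CC1` was tested in a functional assay on OVCAR-3 cells (Homo sapiens) for inhibition, read by sulforhodamine B assay, with a stated time of 48 h (a lower number here means a stronger inhibitor of growth, a higher number a weaker inhibitor of growth), where compound 2 gives 5500 nM. Among the measured compounds shown here, of the two numbers available this is the lower one, yet its only neighbour, compound 1 `CC1=CC[C@H](C(C)(C)NC(=S)N/N=C/c2ccccc2)CC1`, gives 8700 nM, and the step of a 1.6-fold lower number from compound 1 to compound 2 (0.20 log units; within the scatter) lies within the scatter, so these two compounds cannot be told apart on the data at hand. Compound 3 `CC1=CC[C@H](C(C)(C)NC(=S)N/N=C/c2ccc(Cl)cc2)CC1` has not yet been measured. It differs from compound 2 by 4-chlorophenyl in place of 2-hydroxyphenyl on a carbon with a double bond to nitrogen. For the measured compounds named here, no measured step exchanges one ring substituent for another; the single step available, a 1.6-fold lower number from compound 1 to compound 2 (0.20 log units; within the scatter), only adds a hydroxy group and stays within the scatter. Going by the values given here, with no direct precedent, the expectation for compound 3 is a step of a 1.3-fold higher number from compound 2 to compound 3 (0.10 log units; within the scatter) that remains within the scatter. Compound 3 is therefore estimated to give 7000 nM, with a range from 2500 nM to 20000 nM.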

Compound 3, concentration for 50% growth inhibition: 8600 nM
For compound 3 the middle estimate is 1.2-fold (0.09 log units) below the measured one; the range from low to high includes it.
By their numbers in this assay, from the lowest: compounds 2, 3 and 1 (each within the scatter of the next).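

In this assay, the exchange of 2-hydroxyphenyl for 4-chlorophenyl on the carbon with a double bond to nitrogen gives a 1.6-fold higher number from compound 2 to compound 3 (0.19 log units; within the scatter) and the addition of chloro to the unsubstituted ring gives a 1.0-fold lower number from compound 1 to compound 3 (0.01 log units; within the scatter) so neither step can be read as a real change. The earlier pair covered only the addition of a hydroxy group, whereas this result shows that a ring with a hydrogen-bond donor and acceptor and a ring with neither cannot be told apart here. Nothing measured on these compounds offers an explanation for how close their numbers lie.

Going by these compounds, whether any group on this ring can move the number beyond the scatter remains open, for example an amine or a carboxylic acid. Also open, on these data alone, is what would happen if a longer chain carrying the ring stood at this carbon.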